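Adding bromo to compound 3: working notes

The source may hold more compounds than are shown below. What is called first, only, known or untested is meant among the compounds shown, and "the series" means these compounds.

Measured in a functional assay on BV-2 cells (Mus musculus), read by Griess assay, with a stated time of 24 h; a higher number here means a weaker inhibitor, a lower number a stronger inhibitor:
compound 1 `CC1COC2(C=CC(=O)C=C2)N(c2ccccc2)C1=O` 1220 nM
compound 2 `C=CCC1COC2(C=CC(=O)C=C2)N(c2ccccc2)C1=O` 1030 nM
compound 3 `O=C1C=CC2(C=C1)OCC(Cc1ccccc1)C(=O)N2c1ccccc1` 570 nM

The series shows a 2.1-fold lower number from compound 1 to compound 3 (0.33 log units; beyond the scatter), and also a 1.8-fold lower number from compound 2 to compound 3 (0.26 log units; within the scatter). Compound 3 is therefore separated from compound 1 only, while its gap to compound 2 does not clear the scatter.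

Compound 4 `O=C1C=CC2(C=C1)OCC(Cc1ccc(Br)cc1)C(=O)N2c1ccccc1` has bromo in place of hydrogen on an aromatic carbon, para to a large group, which turns benzyl to 4-bromobenzyl: bromo in place of hydrogen on an aromatic carbon. Going by the values given here, no measured step changes that aromatic ring, so the data give no direct reading. The closest evidence is the modest phenyl-for-hydrogen change on the saturated chain carbon, a 2.1-fold lower number from compound 1 to compound 3 (0.33 log units; beyond the scatter), and the vinyl-for-hydrogen change there, a 1.2-fold lower number from compound 1 to compound 2 (0.07 log units; within the scatter). Neither is large, so only a small shift in this assay is expected, with a slight lean towards a lower number at most. The expected step is a 1.1-fold lower number from compound 3 to compound 4 (0.06 log units; within the scatter), which is no firm change. For compound 4 the estimate is 500 nM, with an expected range from 220 nM to 1100 nM.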

Compound 4, half-maximal inhibitory concentration: 1380 nM
Compound 4: middle estimate off by 2.8-fold (0.44 log units), on the low side; measured number above the stated range.
By their numbers in this assay, from the lowest: compounds 3, 2, 1 and 4 (each within the scatter of the next, the first and the last beyond it).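

In this assay, going by these compounds alone, the aromatic ring of the benzyl group proves sensitive to substitution: bromo in place of hydrogen on an aromatic carbon, para to a large group, gives a 2.4-fold higher number from compound 3 to compound 4 (0.38 log units; beyond the scatter) and is the only step here beyond the scatter towards a higher number. The separation of compound 3 from compound 1 does not carry over to the 4-bromobenzyl group, which shows a 1.1-fold higher number from compound 1 to compound 4 (0.05 log units; within the scatter) and a 1.3-fold higher number from compound 2 to compound 4 (0.13 log units; within the scatter) so that compound 4 cannot be told apart from either compound. The data shown give no explanation for the step from hydrogen to bromo.

Going by these compounds, whether this step is specific to bromo stays open, and fluoro, methoxy or an amine on the same aromatic carbon would test that. On these data alone, the effect of bromo on the other carbons of this ring also remains open.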